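The compounds below may be only part of what the source reports. "The series", "measured", "known", "first", "only" and "open" are said of these compounds alone.

Two compounds share one core and differ only in the group that sits on the sulfonyl sulfur. Compound 1 `Cc1ccc(S(=O)(=O)N2CCCC[C@H]2CC(=O)N[C@@H]2CCCc3cc(CNC(C)(C)C)ccc32)cc1Cl` carries a chloro group there, and compound 2 `Cc1ccc(S(=O)(=O)N2CCCC[C@H]2CC(=O)N[C@@H]2CCCc3cc(CNC(C)(C)C)ccc32)cc1C(F)(F)F` carries a trifluoromethyl group in its place. In a functional assay for inhibition of B1 bradykinin receptor (Homo sapiens), read by calcium flux (on this read-out lower numbers stand for stronger inhibition and higher numbers for weaker inhibition), compound 1 gives 22 nM, and compound 2 gives 16 nM. The step of a 1.4-fold lower number from compound 1 to compound 2 (0.14 log units; within the scatter) stays within the scatter. Among the two numbers shown, that of compound 2 is the smaller, yet the gap to compound 1 lies within the scatter, so the two cannot be told apart. Compound 3 `CC(C)(C)NCc1ccc2c(c1)CCC[C@H]2NC(=O)C[C@@H]1CCCCN1S(=O)(=O)c1cccc2cnccc12` has not yet been measured. It differs from compound 2 in one place: isoquinolin-5-yl in place of 4-methyl-3-(trifluoromethyl)phenyl on a sulfonyl sulfur. Within the data shown here, the only measured step, a 1.4-fold lower number from compound 1 to compound 2 (0.14 log units; within the scatter), concerns a single substituent on that same ring and was within the scatter, so it says little about exchanging the whole group for another. Among the measured compounds shown here, no measured pair covers such an exchange, so the direction in this assay is open, and the expected step of a 2.5-fold higher number from compound 2 to compound 3 (0.40 log units; beyond the scatter) is held as uncertain. Compound 3 is therefore estimated at 40 nM, with a range from 8 nM to 200 nM.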

Compound 3, half-maximal inhibitory concentration: 4300 nM
For compound 3 the middle estimate is 110-fold (2.03 log units) below the measured one; measured number above the stated range.
By their numbers in this assay, from the lowest: compounds 2 and 1 (each within the scatter of the next); then compound 3.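

In this assay, the group on the sulfonyl sulfur turns out to matter far more than the earlier pair could show. Putting isoquinolin-5-yl in place of 4-methyl-3-(trifluoromethyl)phenyl raises the number sharply (a 270-fold higher number from compound 2 to compound 3 (2.43 log units; beyond the scatter)), and putting it in place of 3-chloro-4-methylphenyl does much the same (a 200-fold higher number from compound 1 to compound 3 (2.29 log units; beyond the scatter)), so both steps are large, whereas exchanging chloro for trifluoromethyl stayed within the scatter. The incoming group adds a second aromatic ring and a ring nitrogen counted as a hydrogen-bond acceptor, but no measurement at hand explains why the number rises so far.

The compounds shown cannot separate the second ring from the ring nitrogen, and a naphthalen-1-yl group, which has two aromatic rings of carbon only, would help to tell these two changes apart. Also open, as far as these compounds go, is how much room the single phenyl ring offers, for instance whether an amine or a carboxylic acid in place of the chloro or trifluoromethyl group would keep the number as low as in compound 2.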